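The compounds below may be only part of what the source reports. "The series", "measured", "known", "first", "only" and "open" are said of these compounds alone.

Compound 1 `CC(=N)NCC1CCCc2cc(S(=O)(=O)c3ccccc3)ccc21`, compound 2 `O=C(NC[C@@H]1CCCc2cc(S(=O)(=O)c3cccc(F)c3)ccc21)c1ncc[nH]1` and compound 3 `O=C(NC[C@@H]1CCCc2cc(S(=O)(=O)c3cccc(F)c3)ccc21)[C@H]1CCCN1` share one core, a sulfonyl-linked phenyl and a side chain on the saturated ring. In an assay on isolated protein for displacement of a labelled ligand from 5-hydroxytryptamine receptor 6 (Homo sapiens) (on this read-out higher numbers stand for weaker inhibition and lower numbers for stronger inhibition), compound 1 gives 0.631 nM, compound 2 gives 15.9 nM and compound 3 gives 0.631 nM. Compound 3 thus stands level with compound 1 at the digits shown, the two together the lowest numbers of the three, while the single measured step at this position, a 25-fold lower number from compound 2 to compound 3 (1.40 log units; beyond the scatter), is large. Compound 4 `N=C(N)NC(=O)C[C@@H]1CCCc2cc(S(=O)(=O)c3cccc(F)c3)ccc21` differs from compound 3 in the side chain: a group of 6 heavy atoms (2 carbon, 3 nitrogen, 1 oxygen; no ring) in place of a group of 8 heavy atoms (5 carbon, 2 nitrogen, 1 oxygen; one five-membered non-aromatic ring with 1 hetero atom), on a saturated chain carbon bound to a saturated ring carbon. Going by the values given here, no measured pair covers this exchange; the step from compound 2 to compound 3 concerns other groups, and compound 1 carries yet another group, so the numbers of compound 1 and compound 3 show only that a low value is reached with or without the five-membered non-aromatic ring. For compound 4 a step within the scatter, or a small rise, is expected in this assay, a 3.2-fold higher number from compound 3 to compound 4 (0.50 log units; beyond the scatter). Compound 4 is estimated at 2 nM, range 0.4 nM to 10 nM.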

Compound 4, inhibition constant: 0.631 nM
Compound 4: middle estimate off by 3.2-fold (0.50 log units), on the high side; the measured number falls inside the stated range.
By their numbers in this assay, from the lowest: compounds 1, 3 and 4 (each within the scatter of the next); then compound 2.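

Replacing ((pyrrolidin-2-yl)carbonyl)amino with the open group of 6 heavy atoms gives no change at the digits printed from compound 3 to compound 4 (within the scatter) in this assay and shows that the five-membered non-aromatic ring is not required for a low number at this place. Set against the group carrying 1H-imidazol-2-yl, the same open group gives a 25-fold lower number from compound 2 to compound 4 (1.40 log units; beyond the scatter) and so reaches the low level that the pyrrolidin-2-yl group also reached. On a saturated chain carbon bound to a saturated ring carbon, a low number is thus reached with or without a ring, and among these side chains only the one with the aromatic ring stands apart.

On these data alone, it remains open which part of the open group sustains this level, a question that a primary amine or a carboxylic acid on the same chain would address. No supporting data bear on why these side chains give these numbers.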